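The compounds below may be only part of what the source reports. "The series", "measured", "known", "first", "only" and "open" are said of these compounds alone.

The study concerns a set of amide-linked compounds examined in an assay on HEK293 cells for activation of Kir3.1/Kir3.2 (Homo sapiens), read by thallium flux; on this read-out higher numbers stand for an effect only at larger amounts of compound and lower numbers for an effect already at smaller amounts. Compound 1 `Cc1cc(NC(=O)Cn2nnc(-c3ccccc3)n2)n(C(C)C)n1` gives 556 nM in this assay. Among the compounds with values here, compound 2 `Cc1cc(NC(=O)Cn2nnc(-c3cccnc3)n2)n(C2CCCCC2)n1` gives 1930 nM in this assay, the higher of the two numbers measured so far, and its gap from compound 1 lies beyond the usual scatter of repeated measurements. Within the data shown here, no single-point step between measured compounds is available, so the two values can only be set side by side.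

Compound 3 `Cc1cc(NC(=O)Cn2nnc(-c3ccc(C(F)(F)F)cc3)n2)n(C2CCCCC2)n1` has not yet been measured in this assay. It differs from compound 2 in one place: 4-(trifluoromethyl)phenyl in place of pyridin-3-yl on an aromatic carbon. On the present evidence, compound 3 is expected to show a moderate step in this assay, a 2.1-fold lower number from compound 2 to compound 3 (0.33 log units; beyond the scatter), toward a lower number than compound 2, because compound 1, which also carries an aromatic ring of carbon only at that position, gives 556 nM. The estimate for compound 3 is therefore 900 nM, with a range from 300 nM to 2500 nM, and the measured value will tell whether the step proves real.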

Compound 3, half-maximal effective concentration: 241 nM
The estimate for compound 3 lay 3.7-fold (0.57 log units) above the measured number, and the stated range ends above it.
By their numbers in this assay, from the lowest: compound 3; then compound 1; then compound 2.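

In this assay, within the data shown here, putting 4-(trifluoromethyl)phenyl in place of pyridin-3-yl on the aromatic carbon of the five-membered ring with 4 nitrogen gives an 8.0-fold lower number from compound 2 to compound 3 (0.90 log units; beyond the scatter), the first change in this set that can be read in one place alone. It shows that the number responds clearly to what sits at this position while the rest of the molecule stays the same, and that a six-membered aromatic ring of carbon only, carrying trifluoromethyl and no hydrogen-bond acceptor, is tolerated there and goes with the lower number. Nothing available accounts for the size of this step, which changes the count of heavy atoms and removes the ring nitrogen in the same move.

The compounds shown leave open how the step divides between the loss of the ring nitrogen and the gain of the trifluoromethyl group. They also leave open how a 4-methoxyphenyl or 4-chlorophenyl group, or a carboxylic acid on the same ring, would read at this position.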